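Swapping thiophen-2-yl for ethynyl on a shared nucleoside core

A few compounds are considered here, and "the series" means these few. Any claim that something is new, unique, unknown or untested is made for them only; others in the source may bear on it.

Compound 1 `Cc1nc(N)c2c(-c3cccs3)cn([C@@H]3O[C@H](CO)[C@@H](O)[C@H]3O)c2n1`, compound 2 `COc1nc(N)nc2c1c(-c1cccs1)cn2[C@@H]1O[C@H](CO)[C@@H](O)[C@H]1O` and compound 3 `C#Cc1cn([C@@H]2O[C@H](CO)[C@@H](O)[C@H]2O)c2nc(C)nc(N)c12` were tested in a functional assay on HCT-116 cells (Homo sapiens), read by MTT assay, with a stated time of 72 h; on this read-out lower numbers stand for stronger inhibition and higher numbers for weaker inhibition. For compound 1 the reading is only a limit of the assay, > 20000 nM. For compound 2 the reading is likewise a limit, > 20000 nM. For compound 3 the reading is again a limit, > 20000 nM. The change from compound 1 to compound 3 is ethynyl in place of thiophen-2-yl on an aromatic carbon, and its step is a step that the two limits leave unreadable from compound 1 to compound 3, because all three readings sit at the limit of > 20000 nM in this assay, at which 3 of the 3 values shown sit. The difference between the cores of compound 1 and compound 2 is not broken down here. Compound 4 `C#Cc1cn([C@@H]2O[C@H](CO)[C@@H](O)[C@H]2O)c2nc(N)nc(OC)c12`, not yet measured, arises from compound 2 by the same change, (ethynyl in place of thiophen-2-yl on an aromatic carbon). Since the step from compound 1 to compound 3 is a step that the two limits leave unreadable from compound 1 to compound 3, compound 4 is expected to give 30000 nM in this assay, between 10000 nM and 100000 nM. The expected step that the limit leaves unreadable from compound 2 to compound 4 is thus small, and most likely only a limit will again be reported.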

Compound 4, half-maximal inhibitory concentration: > 20000 nM
Compound 4 gave a limit, no number (the forecaster's own chance of this, stated with the estimate: 90%); the middle value lies beyond the limit too.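

No step can be read between compound 2 and compound 4, because both readings are limits and not numbers: the limit of > 20000 nM in this assay, at which 4 of the 4 values shown sit.

The compounds shown leave open how strongly any of the four inhibits in this assay, and whether thiophen-2-yl or ethynyl gives the stronger inhibition.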